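Saturated ester in place of the acrylamide on the pyridine

The source may hold more compounds than are shown below. What is called first, only, known or untested is meant among the compounds shown, and "the series" means these compounds.

Three compounds of the series carry the same biaryl core and differ only in the group on the aromatic carbon that sits ortho to the large group and opposite the ring nitrogen. Compound 2 `CNC(=O)/C=C/c1ccncc1-c1ccc2ccccc2c1` gives 101% in an assay on a protein complex for inhibition of CDK8/Cyclin C (Homo sapiens), with a stated time of 1 h, tested at 10 uM (a lower number here means less inhibition, a higher number more inhibition at the concentration tested (going by the name of the read-out)), the highest of the three numbers. Compound 1 `CC(C)[C@@H](NC(=O)/C=C/c1ccncc1-c1ccc2ccccc2c1)C(=O)O` gives 77% and compound 3 `O=C(O)[C@@H]1CCCN1C(=O)/C=C/c1ccncc1-c1ccc2ccccc2c1` gives 67%. The step of a number 24 percentage points higher from compound 1 to compound 2 (beyond the scatter) and the step of a number 34 percentage points lower from compound 2 to compound 3 (beyond the scatter) both lie beyond the scatter, while a number 10 percentage points lower from compound 1 to compound 3 (within the scatter) does not.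

Compound 4 `COC(=O)CCc1ccncc1-c1ccc2ccccc2c1` has not yet been measured. Its change from compound 2 is 2-(methoxycarbonyl)ethyl in place of 2-(methylcarbamoyl)ethenyl on an aromatic carbon. The measured steps all vary the substituent on the amide-type nitrogen and leave the 2-(methylcarbamoyl)ethenyl linkage itself intact; none of them touches the ethenyl or the amide as such, so they bear on the new step only loosely. They do show that the amide end is sensitive, with a modest rise in a number 24 percentage points higher from compound 1 to compound 2 (beyond the scatter) and a large fall in a number 34 percentage points lower from compound 2 to compound 3 (beyond the scatter), and that compound 3, which like compound 4 has no hydrogen-bond donor in this group, gives the lowest number of the three.

The expectation is therefore a sizeable drop, a number 56 percentage points lower from compound 2 to compound 4 (beyond the scatter), and compound 4 is estimated at 45%, within 15% to 80%.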

Compound 4, a percentage reported as inhibition, at one concentration (the size of the read-out at that concentration, not a potency): 98%
Beside the measured number, compound 4's estimate is 53 percentage points below it; measured number above the stated range.
By their numbers in this assay, from the lowest: compounds 3 and 1 (each within the scatter of the next); then compounds 4 and 2 (each within the scatter of the next).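

In this assay, for the compounds shown here, the earlier steps changed only the substituent on the amide-type nitrogen, whereas this one replaces the linkage and the amide together, and 2-(methoxycarbonyl)ethyl in place of 2-(methylcarbamoyl)ethenyl gives a number 3 percentage points lower from compound 2 to compound 4 (within the scatter). On this aromatic carbon, ortho to a large group and opposite the ring nitrogen, the series therefore keeps its read-out at the concentration tested without the amide hydrogen and without the double bond of the ethenyl linkage, so the sensitivity seen among compound 1, compound 2 and compound 3 does not extend to this change. No measurement on hand accounts for this result, and the single-concentration read-out gives no potency for either compound.

From the compounds shown here alone, the step changes the double bond and the amide at once, so the separate contribution of each stays open, as would be read from a saturated methyl amide or an unsaturated methyl ester on the same core. Also open, going by these compounds, is whether the number stays level with other end groups on the saturated chain, such as a free carboxylic acid, a primary amine or a longer alkyl chain.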